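Trifluoromethoxy in Place of Trifluoromethyl on Compound 1

This account rests on a few compounds, and the source may have more. Where it says the series, first, only, none or still open, it means among the compounds named here.

Measured so far:
compound 1 `O=C(/C=C/c1ccc(C(F)(F)F)cc1)c1ccccc1O` — > 10000 nM
compound 2 `O=C(/C=C/c1ccc(C(F)(F)F)cc1)c1ccc(O)cc1` — > 10000 nM

Of the compounds shown here, two have been tested in a functional assay on RAW264.7 cells (Mus musculus) for inhibition, read by fluorescence, with stated times of 1 h, 24 h and 30 min; a lower number here means a stronger inhibitor, a higher number a weaker inhibitor. Compound 1 gives no number there but only a limit, > 10000 nM. Compound 2 likewise gives only a limit, > 10000 nM. The two differ by a 4-hydroxyphenyl in place of a 2-hydroxyphenyl on the carbonyl carbon, yet the step that the two limits leave unreadable from compound 1 to compound 2 cannot be read, since both results sit at the same limit (the limit of > 10000 nM in this assay, at which 2 of the 2 values shown sit). Compound 1 therefore stands nowhere on a measured scale; all that is known is that it is weaker than the assay can resolve.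

Compound 3 `O=C(/C=C/c1ccc(OC(F)(F)F)cc1)c1ccccc1O` differs from compound 1 by trifluoromethoxy in place of trifluoromethyl on an aromatic carbon. Among the measured compounds shown here, no measured step touches this part of the molecule, and the one step that exists gives no size to lean on. Nothing seen so far suggests that this change would pull the value down into the readable range. Compound 3 is therefore estimated at 15000 nM, within 5000 nM to 50000 nM, most probably reported again as a limit. The expected step that the limit leaves unreadable from compound 1 to compound 3 is none beyond the scatter.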

Compound 3, half-maximal inhibitory concentration: > 10000 nM
Compound 3: no number, only a limit (the forecaster's own chance of this, stated with the estimate: 75%); the middle value lies beyond the limit too.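

Compound 3, like compound 1, gives only a limit in this assay, so no step between compound 1 and compound 3 can be read: the limit of > 10000 nM in this assay, at which 3 of the 3 values shown sit.

The compounds shown leave open how far compound 1, compound 2 and compound 3 each lie beyond that limit, and whether any change to the shared core gives a readable value.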